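Notes on compounds 1 to 3: chloro to trifluoromethyl

The source may report more compounds than this note shows. Statements on the series, on what has been measured and on what is new or still open speak of the compounds shown alone.

Compound 1 `O=C1c2ccccc2S(=O)(=O)N1CCCCCCN1CCN(c2ccccc2Cl)CC1` is the reference point. In an ADME assay on HEK293 cells for displacement of a labelled ligand from 5-hydroxytryptamine receptor 7 (Homo sapiens), read by radioligand binding, with a stated time of 1 h (on this read-out lower numbers stand for stronger inhibition and higher numbers for weaker inhibition), compound 1 gives 120 nM, the higher of the two numbers in hand. Compound 2 `O=C1c2ccccc2S(=O)(=O)N1CCCCCCN1CCN(c2cccc(Cl)c2Cl)CC1` carries an added chloro on an aromatic carbon; in this assay compound 2 gives 119 nM. The step of a 1.0-fold lower number from compound 1 to compound 2 (0.00 log units; within the scatter) is within the scatter, so the two compounds read alike on this read-out.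

Compound 3 `O=C1c2ccccc2S(=O)(=O)N1CCCCCCN1CCN(c2ccccc2C(F)(F)F)CC1` is not yet measured. It differs from compound 1 by trifluoromethyl in place of chloro on an aromatic carbon of a six-membered aromatic ring of carbon only, ortho to a large group; one bond further out this reads 2-chlorophenyl to 2-(trifluoromethyl)phenyl. Going by the values given here, no measured step covers this exchange. Among the compounds with values here, the only step available, a 1.0-fold lower number from compound 1 to compound 2 (0.00 log units; within the scatter), concerns an added chloro elsewhere on the ring and stayed within the scatter, so the one change tried on that ring moved nothing. Within the data shown here, with no direct precedent, the expected step is a 1.1-fold higher number from compound 1 to compound 3 (0.03 log units; within the scatter), a movement that is not expected to exceed the scatter. Compound 3 is estimated at 130 nM in this assay, within 50 nM to 350 nM.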

Compound 3, inhibition constant: 195 nM
For compound 3 the middle estimate is 1.5-fold (0.18 log units) below the measured one; low and high end bracket the measured number.
By their numbers in this assay, from the lowest: compounds 2, 1 and 3 (each within the scatter of the next).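

Compound 3 replaces the chloro that is ortho to a large group, whereas compound 2 kept that chloro and added a second one, and in this assay this exchange gives (a 1.6-fold higher number from compound 1 to compound 3 (0.21 log units; within the scatter)). Going from 2,3-dichlorophenyl on the amine nitrogen in a ring to 2-(trifluoromethyl)phenyl gives (a 1.6-fold higher number from compound 2 to compound 3 (0.21 log units; within the scatter)), so compounds 1, 2 and 3 all read alike on this read-out, and the position takes trifluoromethyl, with 4 heavy atoms, as well as chloro, with 1, without a step that leaves the scatter. No measurement of any property of these groups stands beside the binding numbers, so the series offers an observation here and no explanation of it.

All three compounds carry only chloro or trifluoromethyl on this ring, which leaves open whether a methoxy, a nitrile or an amine at the same place would give a step beyond the scatter. Going by these compounds alone, also open is whether this ring would read the same way with a shorter chain in place of the one in compound 1, or whether the flat response seen here holds only for that chain.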